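Working notes: from compound 1 to compound 4

A few compounds are considered here, and "the series" means these few. Any claim that something is new, unique, unknown or untested is made for them only; others in the source may bear on it.

Measured in an ADME assay on L1210 cells (Mus musculus) for cytotoxicity, with a stated time of 48 h; a higher number here means a weaker inhibitor, a lower number a stronger inhibitor:
compound 1 `CC1=CCC[C@](C)(CC/C(C)=C/CC2=C(O)C(=O)C=C(N[C@@H](CO)C(=O)O)C2=O)[C@@H]1C`: > 10 ug/mL (a limit, not a number)
compound 2 `C=C1[C@H](C)CCC[C@]1(C)CC/C(C)=C/CC1=C(O)C(=O)C=C(OC)C1=O`: 2.4 ug/mL
compound 3 `C=C1[C@H](C)CCC[C@]1(C)CC/C(C)=C/CC1=C(O)C(=O)C=C(N[C@H](C(=O)O)C(C)C)C1=O`: 4.4 ug/mL

Compound 1 has no exact value and stands at the limit of > 10 ug/mL in this assay, at which 1 of the 3 values shown sits. Its distance from the two numbered results is therefore unknown.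

Compound 4 `CC1=CCC[C@](C)(CC/C(C)=C/CC2=C(O)C(=O)C=C(NCC(=O)O)C2=O)[C@@H]1C` has not yet been measured. It carries hydrogen in place of hydroxymethyl on a saturated chain carbon bound to an amine nitrogen and a carbonyl carbon, so that (1-carboxy-2-hydroxyethyl)amino becomes (carboxymethyl)amino: hydrogen in place of hydroxymethyl on a saturated chain carbon bound to an amine nitrogen and a carbonyl carbon.

Within the data shown here, no measured step makes this same exchange. Among the measured compounds shown here, the only step available is a 1.8-fold higher number from compound 2 to compound 3 (0.26 log units; within the scatter), and it concerns (1-carboxy-2-methylpropyl)amino in place of methoxy, so it bears on the present change only loosely. With that single step inside the scatter, no clear step is expected in this assay, and no direction can be favoured. The starting point is only a limit, so a limit is a likely outcome for compound 4 as well.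

The step expected is an at least 1.1-fold lower number from compound 1 to compound 4 (0.04 log units; that floor lies within the scatter). For compound 4 the estimated value is 9 ug/mL, with an expected range of 4 ug/mL to 20 ug/mL.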

Compound 4, half-maximal inhibitory concentration: 3.5 ug/mL
The estimate for compound 4 lay 2.6-fold (0.41 log units) above the measured number; the whole stated range lies above it.
By their numbers in this assay, from the lowest: compounds 2, 4 and 3 (each within the scatter of the next). At a limit, above all of these: compound 1.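

In this assay, the change from (1-carboxy-2-hydroxyethyl)amino to (carboxymethyl)amino gives an at least 2.8-fold lower number from compound 1 to compound 4 (0.45 log units; beyond the scatter). Unlike the earlier exchange of methoxy for (1-carboxy-2-methylpropyl)amino, a 1.8-fold higher number from compound 2 to compound 3 (0.26 log units; within the scatter), this step shows that removing hydroxymethyl alone, on a saturated chain carbon bound to an amine nitrogen and a carbonyl carbon, can move the number beyond the scatter while the rest of the structure stays the same. The value of compound 1 is a limit and not a number, so the step is a floor and its full size cannot be read: the limit of > 10 ug/mL in this assay, at which 1 of the 4 values shown sits.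

A single pair cannot separate the effect of losing hydroxymethyl from that of having hydrogen at this carbon, and a methyl group or a longer chain such as ethyl in the same place would show whether the number responds to any substituent there or to hydroxymethyl in particular. It also remains open whether the same exchange gives a step of similar size on the core of compound 2, where only the (1-carboxy-2-methylpropyl)amino group of compound 3 is shown.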